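The source may report more compounds than this note shows. Statements on the series, on what has been measured and on what is new or still open speak of the compounds shown alone.

Working notes on the series. The shared core is that of compound 1 `O[C@@H]1Cc2ccccc2N[C@H](c2ccccc2)C1`. In an ADME assay on THP-1 cells (Homo sapiens) for cytotoxicity, read by MTT assay, with a stated time of 72 h (a higher number here means that more compound is tolerated, a lower number that less compound is tolerated), compound 1 gives > 300000 nM, which is a limit of the assay rather than a number. Compound 2 `O[C@@H]1Cc2cc(Cl)ccc2N[C@H](c2ccccc2)C1` carries a chloro group on the fused aromatic ring; in this assay compound 2 gives 188000 nM. Compound 3 `O[C@@H]1Cc2ccccc2N[C@H](c2ccc(F)cc2)C1` carries a fluoro group on the pendant phenyl ring. In this assay compound 3 gives > 300000 nM, again a limit of the assay. Two of the three values shown sit at the limit of > 300000 nM in this assay, at which 2 of the 3 values shown sit, so compound 1 stands at a limit, not at a number.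

The next compound, compound 4 `O[C@@H]1Cc2ccccc2N[C@H](c2cccc(Cl)c2)C1`, differs from compound 1 as follows: chloro in place of hydrogen on an aromatic carbon. For the measured compounds named here, two measured steps bear on it. The step of an at least 1.5-fold lower number from compound 1 to compound 2 (0.20 log units; that floor lies within the scatter) is the only one with a chloro entering, though on the other ring. The step that the two limits leave unreadable from compound 1 to compound 3 has a halogen entering on the same phenyl ring as in compound 4, but its size cannot be read from two limits. Neither step is beyond the scatter, and no change in this assay beyond the scatter is therefore expected for compound 4, with a fair chance that only a limit is reported again. The estimate for compound 4 is 300000 nM, within 150000 nM to 600000 nM, corresponding to an expected step of a number no higher from compound 1 to compound 4 (the limit leaves the size open).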

Compound 4, half-maximal cytotoxic concentration: 167000 nM
Compound 4: middle estimate off by 1.8-fold (0.25 log units), on the high side; the measured number falls inside the stated range.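

In this assay, chloro in place of hydrogen on the pendant phenyl ring, meta to a large group, gives compound 4 a readable number, and the change comes out as an at least 1.7-fold lower number from compound 1 to compound 4 (0.25 log units; that floor lies within the scatter). Until now only the fused aromatic ring had shown a chloro group with a readable number, in compound 2; the pendant phenyl ring now shows one as well, and since neither floor lies beyond the scatter, these compounds do not tell the two rings apart. Both steps have only a floor, not a size, because compound 1 stands at a limit: the limit of > 300000 nM in this assay, at which 2 of the 4 values shown sit.

The compounds shown leave open whether any change on the pendant phenyl ring moves the number beyond the scatter, for instance an amine or a carboxylic acid in place of the chloro group at this same position. They also leave open what a chloro group does elsewhere on that ring, and what follows when the hydroxyl group of the shared core is replaced by a methoxy group.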